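The source may hold more compounds than are shown below. What is called first, only, known or untested is meant among the compounds shown, and "the series" means these compounds.

Compound 3, `CN1CCN(CCCN(C(=O)Nc2ccc(F)c(Cl)c2)C2CCc3ccc(S(=O)(=O)N(C)C)cc3C2)CC1`, sits at the weaker end of the three numbers gathered so far. In an assay on CHO cells for binding affinity to melanin-concentrating hormone receptor 1 (Homo sapiens) (a higher number here means a weaker inhibitor, a lower number a stronger inhibitor), compound 3 gives 3000 nM, and compound 2, `CNS(=O)(=O)c1ccc2c(c1)CC(N(CCCN1CCN(C)CC1)C(=O)Nc1ccc(F)c(Cl)c1)CC2`, gives 3000 nM; the two are level at the digits shown, and the step of no change at the digits printed from compound 2 to compound 3 (within the scatter) stays within the scatter. Compound 1, `COc1ccc2c(c1)CCC(N(CCCN1CCN(C)CC1)C(=O)Nc1ccc(F)c(Cl)c1)C2`, gives 190 nM, a lower number than either, but compound 1 is not a single-change neighbour of compound 3, so its value is reported here only as a point of reference.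

Compound 4, `CCNC(=O)Nc1ccc2c(c1)CC(N(CCCN1CCN(C)CC1)C(=O)Nc1ccc(F)c(Cl)c1)CC2`, is the next member of the series and has not yet been measured in this assay. It differs from compound 3 in one place: (ethylcarbamoyl)amino in place of dimethylsulfamoyl on an aromatic carbon. For the measured compounds named here, the only measured step on this part of the shared core, that from compound 2 to compound 3, moved the number by nothing beyond the scatter, and no measured pair shows a sulfonamide being exchanged for a urea. The expectation is therefore drawn loosely: a modest move toward a lower number, with a wide range around it.

On that basis the expected step of a 2.0-fold lower number from compound 3 to compound 4 (0.30 log units; within the scatter) is small, and compound 4 is estimated at 1500 nM, between 300 nM and 7000 nM.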

Compound 4, inhibition constant: 160 nM
Compound 4: middle estimate off by 9.4-fold (0.97 log units), on the high side, and the stated range ends above it.
By their numbers in this assay, from the lowest: compounds 4 and 1 (each within the scatter of the next); then compounds 2 and 3 (each within the scatter of the next).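

Up to this point, the shared core had been seen at this aromatic carbon only with sulfonamide groups, and methyl in place of hydrogen on the sulfonamide nitrogen gave no change at the digits printed from compound 2 to compound 3 (within the scatter) in this assay. Exchanging the whole group has a far greater effect: (ethylcarbamoyl)amino in place of dimethylsulfamoyl gives a 19-fold lower number from compound 3 to compound 4 (1.27 log units; beyond the scatter), and (ethylcarbamoyl)amino in place of methylsulfamoyl gives a 19-fold lower number from compound 2 to compound 4 (1.27 log units; beyond the scatter), so the number at this position clearly depends on which group is attached, although the sulfonamide nitrogen substitution alone left it level. No independent measurement accompanies these steps to account for their size.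

The compounds shown carry only one example of the entering group, so they do not separate the contribution of its ethyl from that of the rest of (ethylcarbamoyl)amino. From the compounds shown here alone, it remains open whether a methyl or a longer chain in place of that ethyl, or a simple amine or an acetamide on the same aromatic carbon, would keep the number as low in this assay.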